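Second Ring Chloro Added to the Ortho Benzyl Purine

This account rests on a few compounds, and the source may have more. Where it says the series, first, only, none or still open, it means among the compounds named here.

Three compounds have been measured in a functional assay on A549 cells (Homo sapiens) for cytotoxicity, read by sulforhodamine B assay, with a stated time of 48 h; on this read-out higher numbers stand for weaker inhibition of growth and lower numbers for stronger inhibition of growth:

compound 1 `ClCc1cccc(Cn2cnc3ncnc(Cl)c32)c1`: 39800 nM
compound 2 `ClCc1ccccc1Cn1cnc2ncnc(Cl)c21`: 24000 nM
compound 3 `ClCc1cccc(Cn2cnc3nc(Cl)nc(Cl)c32)c1`: 25700 nM

Compound 1 and compound 2 are built from the same atoms joined differently; how their two cores differ is not broken down here. Compound 3 arises from compound 1 by chloro in place of hydrogen on an aromatic carbon, and that change gave a 1.5-fold lower number from compound 1 to compound 3 (0.19 log units; within the scatter). Compound 4 `ClCc1ccccc1Cn1cnc2nc(Cl)nc(Cl)c21`, not yet measured, arises from compound 2 by chloro in place of hydrogen on an aromatic carbon, the same change at the same place.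

For compound 4 the expected step is a 1.3-fold lower number from compound 2 to compound 4 (0.10 log units; within the scatter) in this assay, an expectation that rests on the step that the same change produced, because the earlier step was a 1.5-fold lower number from compound 1 to compound 3 (0.19 log units; within the scatter). Compound 4 is therefore expected to give 19000 nM in this assay, most likely between 9500 nM and 38000 nM.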

Compound 4, concentration for total growth inhibition: 5750 nM
Estimate against measurement, compound 4: 3.3-fold (0.52 log units) above; the whole stated range lies above it.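

Chloro in place of hydrogen on an aromatic carbon, between two ring nitrogen atoms, gave a 4.2-fold lower number from compound 2 to compound 4 (0.62 log units; beyond the scatter) in this assay and so did not repeat the earlier step. The size of the step did not carry from one core to the other: the same change on two cores in this assay, a 1.5-fold lower number (0.19 log units; within the scatter) from compound 1 to compound 3 and a 4.2-fold lower number (0.62 log units; beyond the scatter) from compound 2 to compound 4, 2.7-fold (0.43 log units) apart, beyond the scatter of two such steps. This shows that, for these two pairs, the step on the core of compound 1 was a poor guide to the step on the core of compound 2, but it does not show what sets the gap or how the change would behave on any further core.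

The compounds shown leave open whether an amine or a methoxy group in that place would also differ between the two cores.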